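Adding a Methyl Group to Compound 2's Phenyl Ring

This account rests on a few compounds, and the source may have more. Where it says the series, first, only, none or still open, it means among the compounds named here.

Among the measured compounds shown here, compound 2 `C=C(Br)C(=O)Nc1cccc(-c2cn3nc(-c4ccccc4)sc3n2)c1` gives 600 nM in a functional assay on L1210 cells (Mus musculus) for inhibition, read by cell counting, with a stated time of 2 days (a higher number here means a weaker inhibitor, a lower number a stronger inhibitor), the lower of the two numbers measured so far; compound 1 `C=C(Br)C(=O)Nc1cccc(-c2cn3nc(Cc4ccccc4)sc3n2)c1` gives 3000 nM, and the change a 5.0-fold lower number from compound 1 to compound 2 (0.70 log units; beyond the scatter) lies beyond the scatter. Compound 3 `C=C(Br)C(=O)Nc1cccc(-c2cn3nc(-c4ccc(C)cc4)sc3n2)c1` differs from compound 2 by methyl in place of hydrogen on an aromatic carbon. For the measured compounds named here, no measured step concerns a methyl group placed on this phenyl ring; the only step known swaps benzyl for phenyl. Compound 3 is therefore expected to show a step of a 1.2-fold lower number from compound 2 to compound 3 (0.08 log units; within the scatter) in this assay, staying within the scatter, with an estimated 500 nM and a range from 150 nM to 2000 nM.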

Compound 3, half-maximal inhibitory concentration: 920 nM
Compound 3: middle estimate off by 1.8-fold (0.26 log units), on the low side; the measured number falls inside the stated range.
By their numbers in this assay, from the lowest: compounds 2 and 3 (each within the scatter of the next); then compound 1.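

In this assay a methyl group can sit on the phenyl ring, para to a large group, without a readable cost: a 1.5-fold higher number from compound 2 to compound 3 (0.19 log units; within the scatter) leaves compound 2 and compound 3 indistinguishable. The gap to the benzyl compound also holds, with a 3.3-fold lower number from compound 1 to compound 3 (0.51 log units; beyond the scatter) still beyond the scatter. Nothing available explains either step.

Open, on these data alone, is whether a larger or different group at this carbon, such as ethyl, an amine or a carboxylic acid, would keep the number at this level. Also open, as far as these compounds go, is how a methyl group would fare elsewhere on the ring.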